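Swapping trifluoromethyl for chloro on a diaryl urea

A few compounds are considered here, and "the series" means these few. Any claim that something is new, unique, unknown or untested is made for them only; others in the source may bear on it.

Two measured compounds share one core: compound 1 `COc1cc2cc(Oc3ccc(NC(=O)Nc4cccc(C(F)(F)F)c4)cc3)c(C)nc2cc1OC` and compound 2 `COc1cc2cc(Oc3ccc(NC(=O)Nc4ccc(Cl)c(C(F)(F)F)c4)cc3)c(C)nc2cc1OC`. In a functional assay on SNB-19 cells (Homo sapiens) for inhibition, read by sulforhodamine B assay, with a stated time of 48 h (on this read-out higher numbers stand for weaker inhibition of growth and lower numbers for stronger inhibition of growth), compound 1 gives 2190 nM, and compound 2 gives 1410 nM. Compound 2 holds the lower of the two numbers, yet the step of a 1.6-fold lower number from compound 1 to compound 2 (0.19 log units; within the scatter) lies within the scatter, so the two cannot be separated on these data.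

Compound 3 `COc1cc2cc(Oc3ccc(NC(=O)Nc4ccc(Cl)c(Cl)c4)cc3)c(C)nc2cc1OC` is not yet measured. It differs from compound 2 in one place: chloro in place of trifluoromethyl on an aromatic carbon. Within the data shown here, no measured step makes this same exchange; the only recorded step, from compound 1 to compound 2, concerns a different change and stayed within the scatter. Nothing here points to a real shift for a small exchange on this ring. For compound 3 the expected step is therefore a 1.3-fold higher number from compound 2 to compound 3 (0.11 log units; within the scatter), not beyond the scatter. For compound 3 the estimate in this assay is 1800 nM, with a range from 700 nM to 4500 nM.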

Compound 3, concentration for 50% growth inhibition: 4260 nM
Compound 3: middle estimate off by 2.4-fold (0.37 log units), on the low side; the range from low to high includes it.
By their numbers in this assay, from the lowest: compounds 2, 1 and 3 (each within the scatter of the next, the first and the last beyond it).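

In this assay, among these compounds, the exchange of trifluoromethyl for chloro at this ring position, ortho to a chloro group, gives a 3.0-fold higher number from compound 2 to compound 3 (0.48 log units; beyond the scatter), the only step here beyond the scatter, and a modest one. This shows that growth inhibition at this position can respond to the choice of group, which the addition of chloro to compound 1 did not show. The step across both changes, a 1.9-fold higher number from compound 1 to compound 3 (0.29 log units; within the scatter), stays within the scatter, so compound 3 cannot be separated from compound 1, and only compound 2 and compound 3 stand apart.

Nothing measured here explains why the exchange shifts the number. As far as these compounds go, whether a methyl, a methoxy group or a nitrile at this position would fall nearer compound 2 or compound 3 remains open.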